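Solubility notes on a urea series: compound 3 to compound 4

The source may hold more compounds than are shown below. What is called first, only, known or untested is meant among the compounds shown, and "the series" means these compounds.

Measured so far:
- compound 1, `COc1ccc(NC(=O)Nc2cc(C)nc3ccccc23)cc1`, 19800 nM
- compound 2, `CC(=O)c1ccc(NC(=O)Nc2cc(C)nc3ccccc23)cc1`, 3800 nM
- compound 3, `Cc1cc(NC(=O)Nc2ccc(C(N)=O)cc2)c2ccccc2n1`, 900 nM

In a physicochemical assay for solubility, at pH 7.4 (a lower number here means a less soluble compound, a higher number a more soluble compound), compound 3 gives the lowest of the three numbers: a 22-fold lower number from compound 1 to compound 3 (1.34 log units; beyond the scatter) and a 4.2-fold lower number from compound 2 to compound 3 (0.63 log units; beyond the scatter). Compound 4, `Cc1cc(NC(=O)Nc2ccc(C(C)(C)C)cc2)c2ccccc2n1`, is the next member and has not yet been measured. It differs from compound 3 in one place: tert-butyl in place of carbamoyl on an aromatic carbon. For the measured compounds named here, no measured step swaps these two groups directly. The nearest guide is a 22-fold lower number from compound 1 to compound 3 (1.34 log units; beyond the scatter), since compound 1 carries a group on the same aromatic carbon that, like tert-butyl, is not carbamoyl; the step from compound 2 to compound 3 is a smaller change at the carbonyl carbon. A rise in this assay beyond the scatter is therefore expected for compound 4, of roughly a 6.7-fold higher number from compound 3 to compound 4 (0.82 log units; beyond the scatter), though the size is uncertain. Compound 4 is estimated at 6000 nM, with a range from 1500 nM to 25000 nM.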

Compound 4, solubility: 6200 nM
Compound 4: the middle estimate sits 1.0-fold (0.01 log units) below what was measured; the measured number falls inside the stated range.
By their numbers in this assay, from the lowest: compound 3; then compounds 2 and 4 (each within the scatter of the next); then compound 1.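

For the compounds shown here, at this aromatic carbon, carbamoyl is not the only group that separates from tert-butyl in this assay (a 6.9-fold higher number from compound 3 to compound 4 (0.84 log units; beyond the scatter)). A group with 0 hydrogen-bond donors and 0 hydrogen-bond acceptors need not match methoxy, as the step to tert-butyl from that group shows (a 3.2-fold lower number from compound 1 to compound 4 (0.50 log units; beyond the scatter)), while tert-butyl and acetyl remain unseparated (a 1.6-fold higher number from compound 2 to compound 4 (0.21 log units; within the scatter)). Nothing available explains these steps.

The compounds shown leave open how an amine or a carboxylic acid would read at this aromatic carbon. They also leave open whether a longer chain in place of tert-butyl would stay level with acetyl.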